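Replacing 3-chlorophenyl with methoxycarbonyl on the tetrazole

The compounds below may be only part of what the source reports. "The series", "measured", "known", "first", "only" and "open" are said of these compounds alone.

Measured so far:
compound 1 `CCCCCCCCc1ccc(OCC(=O)Cn2nnc(-c3ccccc3)n2)cc1`: 33%
compound 2 `CCCCCCCCc1ccc(OCC(=O)Cn2nnc(-c3cccc(Cl)c3)n2)cc1`: 69%
compound 3 `CCCCCCCCc1ccc(OCC(=O)Cn2nnc(-c3cccs3)n2)cc1`: 8%

In an ADME assay on S9 fraction from liver (Rattus norvegicus) for metabolic stability, read by LC-MS, using NADPH, with a stated time of 30 min (on this read-out higher numbers stand for a more stable compound and lower numbers for a less stable compound), compound 2 gives 69%, the highest of the three numbers, with compound 1 at 33% and compound 3 at 8% both beyond the scatter below it. The next compound, compound 4 `CCCCCCCCc1ccc(OCC(=O)Cn2nnc(C(=O)OC)n2)cc1`, differs from compound 2 in one place: methoxycarbonyl in place of 3-chlorophenyl on an aromatic carbon.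

Going by the values given here, no measured step swaps this group for an ester, but two steps show what happens when 3-chlorophenyl is left. Going the other way along the step of a number 36 percentage points higher from compound 1 to compound 2 (beyond the scatter), the loss of chloro alone costs a large amount, and the step of a number 61 percentage points lower from compound 2 to compound 3 (beyond the scatter) costs even more. Every measured departure from 3-chlorophenyl therefore lowered the number in this assay, and a drop is expected here too, though its size is uncertain.

Compound 4 is estimated at 25%, within 5% to 55%, which means an expected step of a number 44 percentage points lower from compound 2 to compound 4 (beyond the scatter).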

Compound 4, percent of the compound remaining: < 5%
Compound 4 ended at the assay's limit; the forecaster's own chance of this, stated with the estimate: 5%; middle value at least 20 percentage points from the limit.
By their numbers in this assay, from the lowest: compound 3; then compound 1; then compound 2. At a limit, below all of these: compound 4.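

In this assay compound 4 gives < 5%, which is a limit of the assay and not a number. The earlier compounds shown here all carry an aromatic ring on this carbon of the tetrazole, whereas methoxycarbonyl has no ring. Methoxycarbonyl in place of 3-chlorophenyl gives a number at least 64 percentage points lower from compound 2 to compound 4 (beyond the scatter). Methoxycarbonyl in place of phenyl gives a number at least 28 percentage points lower from compound 1 to compound 4 (beyond the scatter). Methoxycarbonyl in place of thiophen-2-yl gives a number at least 3 percentage points lower from compound 3 to compound 4 (that floor lies within the scatter), so thiophen-2-yl and methoxycarbonyl cannot be ranked here.

With only one ring-free group shown, it remains open whether the loss belongs to ring-free groups in general or to this ester, as a methyl, an amide or a carboxylic acid on the same carbon could tell. As far as these compounds go, it also remains open whether chloro on the phenyl ring would help at any other ring carbon.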